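Replacing the Fluorinated Ring of Compound 1 with Pyridine

A few compounds are considered here, and "the series" means these few. Any claim that something is new, unique, unknown or untested is made for them only; others in the source may bear on it.

Compound 1 `O=C(NCc1ccc(CNS(=O)(=O)c2ccccc2)cc1)c1cccc(F)c1` was tested in an assay on MDA-MB-231 cells for binding affinity to C-X-C chemokine receptor type 4 (Homo sapiens), read by immunofluorescence and microscopy, with stated times of 10 min and 30 min (a lower number here means that less compound is needed, a higher number that more compound is needed for the effect), where compound 1 gives 100 nM. Compound 2 `Cc1ccc(S(=O)(=O)NCc2ccc(CNC(=O)c3ccccc3C)cc2)cc1` gives 100 nM in this assay, so compound 1 stands level with compound 2 at the digits shown, within the scatter. Compound 3 `O=C(NCc1ccc(CNS(=O)(=O)c2ccccc2)cc1)c1ccncc1` has not yet been measured. It differs from compound 1 by pyridin-4-yl in place of 3-fluorophenyl on a carbonyl carbon. Going by the values given here, no comparable step exists among the measured compounds, so the step of a 1.5-fold higher number from compound 1 to compound 3 (0.18 log units; within the scatter) is expected to be small, at most a modest loss, close to the scatter. Compound 3 is estimated at 150 nM, with a range from 50 nM to 500 nM.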

Compound 3, effective concentration (reported as EC, without a stated level of effect): 10 nM
For compound 3 the middle estimate is 15-fold (1.18 log units) above the measured one; the whole stated range lies above it.
By their numbers in this assay, from the lowest: compound 3; then compounds 1 and 2 (each within the scatter of the next).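

In this assay, pyridin-4-yl in place of 3-fluorophenyl on a carbonyl carbon gives a 10-fold lower number from compound 1 to compound 3 (1.00 log units; beyond the scatter), a step beyond the scatter. Going by these compounds alone, the earlier compounds offered no step between compounds differing in one place, so this is the first sign that the group on this carbonyl carbon can shift the number. Nothing measured here accounts for the step. Compound 3 both gains a ring nitrogen and loses the fluorine, and the two changes cannot be separated. From the compounds shown here alone, how a plain phenyl or a pyrimidine ring at this place would read remains open.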